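A hydroxy for chloro swap at one aromatic carbon

The source may hold more compounds than are shown below. What is called first, only, known or untested is meant among the compounds shown, and "the series" means these compounds.

Measured in a functional assay on DU-145 cells (Homo sapiens) for inhibition, read by trypan blue exclusion, with a stated time of 72 h; on this read-out lower numbers stand for stronger inhibition and higher numbers for weaker inhibition:
- compound 1 `COc1ccc(S(=O)(=O)c2cc3cnc(Nc4ccc5[nH]ccc5c4)nc3n(C)c2=O)cc1` gives 500 nM
- compound 2 `Cn1c(=O)c(S(=O)(=O)c2ccc(Cl)cc2)cc2cnc(Nc3ccc4[nH]ccc4c3)nc21` gives 250 nM

In this assay, among the compounds with values here, compound 2 gives 250 nM and stands within the scatter of the only other measured compound. Within the data shown here, the single measured step is chloro in place of methoxy on an aromatic carbon (a 2.0-fold lower number from compound 1 to compound 2 (0.30 log units; within the scatter)).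

The next compound, compound 3 `Cn1c(=O)c(S(=O)(=O)c2ccc(O)cc2)cc2cnc(Nc3ccc4[nH]ccc4c3)nc21`, carries hydroxy in place of chloro on an aromatic carbon, para to a large group (hydroxy in place of chloro on an aromatic carbon). Among the measured compounds shown here, the measured step changes the same place, but it stayed within the scatter, and no measured compound carries hydroxy there. The direction is therefore uncertain, and no step beyond the scatter is expected in this assay. The expected step is small (a 1.6-fold higher number from compound 2 to compound 3 (0.20 log units; within the scatter)). In this assay compound 3 is estimated at 400 nM within a range of 130 nM to 1200 nM (an expectation only).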

Compound 3, half-maximal inhibitory concentration: 250 nM
Beside the measured number, compound 3's estimate is 1.6-fold (0.20 log units) above it; the measured number falls inside the stated range.
By their numbers in this assay, from the lowest: compounds 2, 3 and 1 (each within the scatter of the next).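

In this assay, within the data shown here, hydroxy at this aromatic carbon brings a hydrogen-bond donor to the place for the first time, and replacing chloro with it gives no change at the digits printed from compound 2 to compound 3 (within the scatter). Taking the methyl off the oxygen gives a 2.0-fold lower number from compound 1 to compound 3 (0.30 log units; within the scatter), so with this result all three steps among methoxy, chloro and hydroxy at this one place stay within the scatter, and none of the three groups separates from the others. Nothing on hand speaks to why the number holds across these groups.

The compounds shown leave open whether an amine or a carboxylic acid at this carbon, or a longer chain on the oxygen, would move the number beyond the scatter. They also leave open whether any change at this place can produce a step of that size in this read-out.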